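The compounds below may be only part of what the source reports. "The series", "measured", "known", "first", "only" and "open" are said of these compounds alone.

Measured so far in an assay on membranes from brain for displacement of a labelled ligand from Neuronal acetylcholine receptor; alpha4/beta2 (Rattus norvegicus); on this read-out higher numbers stand for weaker inhibition and lower numbers for stronger inhibition:
compound 1 `CCc1cncc(OC[C@@H]2CCCN2C)c1`, 0.32 nM
compound 2 `CC(=O)c1cncc(OC[C@@H]2CCCN2C)c1`, 1.19 nM

Within the data shown here, compound 2 stands highest of the two numbers; its nearest neighbour is compound 1, and the single measured step, a 3.7-fold higher number from compound 1 to compound 2 (0.57 log units; beyond the scatter), is modest. Compound 3 `CN1CCC[C@H]1COc1cncc([N+](=O)[O-])c1` carries the change (nitro in place of acetyl on an aromatic carbon). Among the measured compounds shown here, no measured step exchanges acetyl for nitro, so only the acetyl-for-ethyl step bears on the case, and a step of no more than that size, or none beyond the scatter, is expected. Compound 3 is therefore expected to give 1 nM in this assay, within 0.3 nM to 3.5 nM, which means a step of a 1.2-fold lower number from compound 2 to compound 3 (0.08 log units; within the scatter).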

Compound 3, inhibition constant: 4.65 nM
Compound 3: the middle estimate sits 4.7-fold (0.67 log units) below what was measured; the whole stated range lies below it.
By their numbers in this assay, from the lowest: compound 1; then compound 2; then compound 3.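

In this assay the position two atoms from the ring nitrogen separates groups with the same heavy-atom count: nitro for acetyl, both of 3 heavy atoms, gives a 3.9-fold higher number from compound 2 to compound 3 (0.59 log units; beyond the scatter) so that count alone does not set the number. Across the three groups the span reaches a 15-fold higher number from compound 1 to compound 3 (1.16 log units; beyond the scatter) and ethyl gives the lowest number of the three. Nothing measured here accounts for these differences. Still open, on these data alone, is where an amine, a carboxylic acid or a longer chain at this position would fall relative to ethyl.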